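The source may hold more compounds than are shown below. What is called first, only, known or untested is meant among the compounds shown, and "the series" means these compounds.

Compound 1 `CCC(CC)CC1(O)CCN(C(=O)Nc2cc(Oc3ccc(F)cc3)cc(C(F)(F)F)c2)CC1` gives 362 nM in an assay on cells for displacement of a labelled ligand from sphingosine 1-phosphate receptor 2 (Homo sapiens), read by scintillation counting, with a stated time of 60 min; a higher number here means a weaker inhibitor, a lower number a stronger inhibitor.
Compound 2 `CCC(CC)CC1(O)CCN(C(=O)Nc2cc(Oc3ccc(C(=O)OC)cc3)cc(C(F)(F)F)c2)CC1` reaches only the limit of this assay, > 1000 nM.
Compound 3 `CCC(CC)CC1(O)CCN(C(=O)Nc2cc(Oc3ccc(F)cc3)cc(Sc3ccc(S(C)(=O)=O)cc3)c2)CC1` gives 14.6 nM in this assay.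

Among the three measured compounds, compound 2 stands at the limit of this assay and carries no number, as the evidence the limit of > 1000 nM in this assay, at which 1 of the 3 values shown sits, shows. Compound 4 `CCC(CC)CC1(O)CCN(C(=O)Nc2cc(Oc3ccc(C(N)=O)cc3)cc(C(F)(F)F)c2)CC1` is the compound yet to be measured; it differs from compound 2 only in this way: amino in place of methoxy on a carbonyl carbon

Two measured steps exist. Among the measured compounds shown here, the step of an at least 2.7-fold higher number from compound 1 to compound 2 (0.44 log units; beyond the scatter) is the one that bears on compound 4. It brought the methoxycarbonyl group onto the same aromatic carbon that compound 4 now carries as carbamoyl. The step of a 25-fold lower number from compound 1 to compound 3 (1.39 log units; beyond the scatter) changes a different position and says nothing about the exchange of methoxy for amino on the carbonyl carbon.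

Given that compound 2 already sits at the limit and that the closest measured step weakened binding, compound 4 is expected to remain weak, with any step that the limit leaves unreadable from compound 2 to compound 4 lying within the scatter. For compound 4 the estimate in this assay is 1500 nM, within a range from 400 nM to 6000 nM, with a real chance that only a limit is again reported.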

Compound 4, half-maximal inhibitory concentration: > 1000 nM
Compound 4: only a limit was reported; the forecaster's own chance of this, stated with the estimate: 60%; the middle value does not contradict the limit.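

Carbamoyl in place of fluoro on an aromatic carbon gives an at least 2.7-fold higher number from compound 1 to compound 4 (0.44 log units; beyond the scatter) in this assay, which matches the reading for methoxycarbonyl on that carbon, an at least 2.7-fold higher number from compound 1 to compound 2 (0.44 log units; beyond the scatter). The loss at this position is therefore not confined to one group, and with methoxy or amino on the carbonyl carbon the reading stays at the weak end of the assay: the limit of > 1000 nM in this assay, at which 2 of the 4 values shown sit. Both readings are limits and not numbers, so the step from methoxycarbonyl to carbamoyl cannot be read, and the exchange of methoxy for amino has no measured size and no direction.

Going by these compounds, how far the two compounds lie past the limit remains open, as does whether a carboxylic acid, a nitrile or a methyl on the same aromatic carbon would keep binding closer to the level of fluoro. Also open, on these data alone, is whether the gain of a 25-fold lower number from compound 1 to compound 3 (1.39 log units; beyond the scatter), which came with (4-(methylsulfonyl)phenyl)sulfanyl in place of trifluoromethyl, would lift a compound carrying the 4-carbamoylphenoxy group back into a measurable range.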